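The compounds below may be only part of what the source reports. "The series", "measured", "known", "first", "only" and "open" are said of these compounds alone.

In a functional assay on MCF7 cells (Homo sapiens) for antiproliferative activity, read by MTT assay, with a stated time of 72 h (on this read-out higher numbers stand for weaker inhibition and lower numbers for stronger inhibition), compound 1 (`CCN1CCN(c2cc(C)c3cc(NC(=O)c4ccc(F)c(F)c4)ccc3n2)CC1`) gives 5230 nM and compound 2 (`CCN1CCN(c2cc(C)c3cc(NC(=O)c4ccc5ccccc5n4)ccc3n2)CC1`) gives 7060 nM as its value, so the two stand level within the usual scatter. Compound 3 (`CCN1CCN(c2cc(C)c3cc(NC(=O)c4ccccc4OC)ccc3n2)CC1`) differs from compound 2 by carrying 2-methoxyphenyl in place of quinolin-2-yl on a carbonyl carbon. For the measured compounds named here, the one measured swap at this place (a 1.3-fold higher number from compound 1 to compound 2 (0.13 log units; within the scatter)) stayed within the scatter, so no step beyond the scatter is expected in this assay for this change. The estimated step (a 1.2-fold lower number from compound 2 to compound 3 (0.07 log units; within the scatter)) is accordingly small. Compound 3 is therefore expected to read about 6000 nM (range 2000 nM to 18000 nM).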

Compound 3, half-maximal inhibitory concentration: 13200 nM
For compound 3 the middle estimate is 2.2-fold (0.34 log units) below the measured one; measured number inside the range.
By their numbers in this assay, from the lowest: compounds 1, 2 and 3 (each within the scatter of the next, the first and the last beyond it).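

In this assay, this place on the carbonyl carbon now shows a step beyond the scatter, though a modest one (a 2.5-fold higher number from compound 1 to compound 3 (0.40 log units; beyond the scatter)), so 2-methoxyphenyl and 3,4-difluorophenyl do not read alike here. Against quinolin-2-yl, the same 2-methoxyphenyl group stays within the scatter (a 1.9-fold higher number from compound 2 to compound 3 (0.27 log units; within the scatter)), so the place responds only slightly across these three groups. No supporting measurement is available to explain this difference. The compounds shown leave open whether an amine, a carboxylic acid or a longer chain carried at this place would shift the number further.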